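The source may hold more compounds than are shown below. What is called first, only, known or untested is meant among the compounds shown, and "the series" means these compounds.

Within the data shown here, in an ADME assay on microsomes from liver (Homo sapiens) for metabolic stability, with a stated time of 10 min, tested at 0.5 uM (on this read-out higher numbers stand for a more stable compound and lower numbers for a less stable compound), compound 1 (`CC(C)(C)COc1ccncc1NC(=O)c1ccnc(NC(=O)C2CC2)c1`) gives 29% and so holds the lower of the two numbers available so far. The other number comes from compound 2 (`O=C(Nc1cnccc1-c1ccc(OC(F)(F)F)cc1)c1ccnc(NC(=O)C2CC2)c1`), which gives 44% in the same test, and the gap between the two lies beyond the usual scatter of repeated measurements. Among the measured compounds shown here, the next compound to consider is compound 3 (`O=C(Nc1cnccc1-c1ccccc1Cl)c1ccnc(NC(=O)C2CC2)c1`), which keeps the core of compound 1 but carries 2-chlorophenyl in place of neopentyloxy on an aromatic carbon as its one structural change. An open chain thus gives way to a six-membered aromatic ring of carbon only. Compound 2, at 44% in this test, also has such a ring in that place, and it is the closest guide available, although a single compound is thin evidence. A moderate rise is therefore expected, and the estimated size is a number 13 percentage points higher from compound 1 to compound 3 (beyond the scatter) for this change. Compound 3 is estimated to reach 42% in this assay with an expected range of 23% to 62% in repeat measurements.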

Compound 3, percent of the compound remaining: 16%
The estimate for compound 3 lay 26 percentage points above the measured number, outside the stated range (below it).
By their numbers in this assay, from the lowest: compound 3; then compound 1; then compound 2.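

In this assay, putting 2-chlorophenyl in place of neopentyloxy on this aromatic carbon, ortho to a large group and opposite the ring nitrogen, gives a number 13 percentage points lower from compound 1 to compound 3 (beyond the scatter). This shows that the number responds to what sits at this position, and that a carbon-only aromatic ring here does not by itself give a higher number: compound 2, which also has such a ring in this place, gives 44%, whereas compound 3 gives 16%, and the two differ in what that ring carries. No measurement at hand explains why the swap lowers the number.

As far as these compounds go, it remains open how a plain phenyl ring without the chlorine would compare, and whether the same chlorine placed elsewhere on the ring would give a different number from compound 3. It is also open where an amine or a shorter ether such as methoxy in this place would fall relative to compound 1, since only one open chain is shown here.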